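Swapping Methyl for Nitro on the Amide Aryl Ring

The source may hold more compounds than are shown below. What is called first, only, known or untested is meant among the compounds shown, and "the series" means these compounds.

Compound 1 `COc1ccccc1NC(=O)c1ccc(/N=N\c2c[nH]c3ccccc23)cc1`: "not active" (no number reported)
Compound 2 `O=C(Nc1ccccc1F)c1ccc(/N=N\c2c[nH]c3ccccc23)cc1`: 106000 nM
Compound 3 `Cc1cccc(NC(=O)c2ccc(/N=N\c3c[nH]c4ccccc34)cc2)c1`: 300 nM

All three compounds share one core and differ only in the substituted phenyl ring attached to the amide nitrogen. In a functional assay on P388 cells (Mus musculus) for inhibition, read by MTT assay, with a stated time of 72 h (on this read-out lower numbers stand for stronger inhibition and higher numbers for weaker inhibition), compound 1 is reported as "not active" (no number reported), so it carries no number. Among the compounds with values here, compound 2 gives 106000 nM in this assay, and compound 3 gives 300 nM, the lowest of the two numbers reported; the single measured step, a 350-fold lower number from compound 2 to compound 3 (2.55 log units; beyond the scatter), is large and beyond the scatter.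

Compound 4 `O=C(Nc1cccc([N+](=O)[O-])c1)c1ccc(/N=N\c2c[nH]c3ccccc23)cc1` is the next step from compound 3: nitro in place of methyl on an aromatic carbon, meta to a large group. Within the data shown here, only the step from compound 2 to compound 3 bears on it, and that step changed both the group and its place on the ring at once, so it does not show how a nitro group compares with a methyl group at the same place. With no direct comparison, the change is expected to cost some activity, with wide uncertainty: the step of a 6.7-fold higher number from compound 3 to compound 4 (0.82 log units; beyond the scatter) is the expected outcome. Compound 4 is therefore estimated at 2000 nM, within a range from 200 nM to 30000 nM.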

Compound 4, half-maximal inhibitory concentration: 51900 nM
The estimate for compound 4 lay 26-fold (1.41 log units) below the measured number; measured number above the stated range.
By their numbers in this assay, from the lowest: compound 3; then compound 4; then compound 2.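

With the place on the ring held fixed, the change from methyl to nitro gives in this assay a 170-fold higher number from compound 3 to compound 4 (2.24 log units; beyond the scatter) and so isolates the effect of the group itself, which the earlier step could not do. Within the data shown here, the 3-nitrophenyl compound also lands much nearer the 2-fluorophenyl compound, with a 2.0-fold lower number from compound 2 to compound 4 (0.31 log units; beyond the scatter) and a far smaller gap than the one separating the two groups at the same place. Having a group at this place is therefore not enough to give a low number, since methyl gives one here and nitro does not, and no measurement at hand explains the difference.

On these data alone, whether an amine, a carboxylic acid or a longer chain at this place would come closer to methyl or to nitro remains open. So does whether methyl would give a similarly low number elsewhere on this ring.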